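A few compounds are considered here, and "the series" means these few. Any claim that something is new, unique, unknown or untested is made for them only; others in the source may bear on it.

Measured so far, in an assay on cells for antagonist activity at transient receptor potential cation channel subfamily V member 1 (Homo sapiens), read by FLIPR and calcium flux, with a stated time of 6 min; a lower number here means a stronger inhibitor, a higher number a weaker inhibitor:
compound 1 `CC(C(=O)NCc1ccc(C(C)(C)C)nc1N1CCC(Cc2ccccc2)CC1)c1ccc(NS(C)(=O)=O)c(F)c1` gives 0.3 nM
compound 2 `CC(C)Oc1nc(C(C)(C)C)ccc1CNC(=O)C(C)c1ccc(NS(C)(=O)=O)c(F)c1` gives 2.3 nM
compound 3 `CC(C)COc1nc(C(C)(C)C)ccc1CNC(=O)C(C)c1ccc(NS(C)(=O)=O)c(F)c1` gives 0.6 nM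

Compound 3 stands second highest of the three numbers: compound 1 reads lower by an amount within the scatter, compound 2 higher by an amount beyond it. For the measured compounds named here, the one step that differs in a single place, a 3.8-fold lower number from compound 2 to compound 3 (0.58 log units; beyond the scatter), shows that replacing isopropyl by isobutyl on the ring oxygen lowered the number modestly.

Compound 4 `CCCCCCSc1nc(C(C)(C)C)ccc1CNC(=O)C(C)c1ccc(NS(C)(=O)=O)c(F)c1` differs from compound 3 by hexylsulfanyl in place of isobutoxy on an aromatic carbon. Going by the values given here, the step from compound 2 to compound 3 bears on this only in part: again a larger alkyl group enters, but sulfur replaces oxygen, and no measured pair speaks to that exchange. A step no larger than the scatter is therefore expected, a 1.3-fold higher number from compound 3 to compound 4 (0.12 log units; within the scatter), in either direction. Compound 4 is estimated at 0.8 nM, with a range from 0.2 nM to 4 nM.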

Compound 4, inhibition constant: 1.5 nM
Compound 4: the middle estimate sits 1.9-fold (0.27 log units) below what was measured, within the range that was stated.
By their numbers in this assay, from the lowest: compounds 1 and 3 (each within the scatter of the next); then compounds 4 and 2 (each within the scatter of the next).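

Hexylsulfanyl on this aromatic carbon next to the ring nitrogen gives a 2.5-fold higher number from compound 3 to compound 4 (0.40 log units; beyond the scatter) and so does not hold the level set by isobutoxy. Against isopropoxy, it gives a 1.5-fold lower number from compound 2 to compound 4 (0.19 log units; within the scatter) and so a sulfur-linked hexyl chain remains in the low range seen with the smaller oxygen-linked group. No measurement at hand accounts for either step.

The compounds shown do not separate the exchange of oxygen for sulfur from the lengthening of the chain. Hexyloxy and isobutylsulfanyl at this carbon would each change only one of the two.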